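Compound 3 to compound 4: replacing the chloro group

The compounds below may be only part of what the source reports. "The series", "measured", "known", "first", "only" and "open" are said of these compounds alone.

Of the compounds shown here, three sharing one core have been measured in a functional assay on MV4-11 cells (Homo sapiens) for inhibition, read by resazurin assay, with a stated time of 72 h; a higher number here means a weaker inhibitor of growth, a lower number a stronger inhibitor of growth. Compound 1 `O=C1NCCC12CCN(c1c(Cl)cncc1-c1ccsc1)CC2` gives 190 nM, compound 2 `O=C1NCCC12CCN(c1c(Cl)cncc1-c1cc[nH]c1)CC2` gives 1050 nM, and compound 3 `O=C1NCCC12CCN(c1c(Cl)cncc1-c1ccc(Cl)s1)CC2` gives 560 nM. Compound 3 cannot be separated from compound 2, since a 1.9-fold lower number from compound 2 to compound 3 (0.27 log units; within the scatter) stays within the scatter. It does stand apart from compound 1, with a 2.9-fold higher number from compound 1 to compound 3 (0.47 log units; beyond the scatter).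

The next structure is compound 4 `O=C1NCCC12CCN(c1c(Cl)cncc1-c1ccc(CN3CCCC3)s1)CC2`, and the change is (pyrrolidin-1-yl)methyl in place of chloro on an aromatic carbon. In words, (pyrrolidin-1-yl)methyl stands in place of chloro on an aromatic carbon, next to the ring sulfur.

For the measured compounds named here, no measured step makes this exchange. The closest guides are replacements of the whole aromatic group: a 5.5-fold higher number from compound 1 to compound 2 (0.74 log units; beyond the scatter) and a 2.9-fold higher number from compound 1 to compound 3 (0.47 log units; beyond the scatter), both modest. Going by the values given here, they indicate a scale but no direction, and no measured compound carries a group of this kind. No step beyond the scatter is therefore expected in this assay, although a modest step either way remains possible.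

The step expected is a 1.2-fold lower number from compound 3 to compound 4 (0.09 log units; within the scatter). For compound 4 the estimated value is 450 nM. The estimated range for compound 4 runs from 120 nM to 1700 nM.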

Compound 4, concentration for 50% growth inhibition: 3370 nM
For compound 4 the middle estimate is 7.5-fold (0.87 log units) below the measured one; measured number outside the range, above it.
By their numbers in this assay, from the lowest: compound 1; then compounds 3 and 2 (each within the scatter of the next); then compound 4.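

In this assay, the aromatic carbon next to the ring sulfur proves sensitive to what it carries: (pyrrolidin-1-yl)methyl in place of chloro gives a 6.0-fold higher number from compound 3 to compound 4 (0.78 log units; beyond the scatter). Unlike the earlier steps, which exchanged the whole aromatic group, this one keeps the five-membered aromatic ring with 1 sulfur and alters only the group at this position, so the step belongs to this single exchange. The entering group brings a five-membered non-aromatic ring with 1 hetero atom and a hydrogen-bond acceptor, neither of which chloro has, but nothing available accounts for the higher number or assigns it to any one of these features.

The compounds shown leave open whether the step follows from the amine nitrogen or from the larger group as a whole, a question that a plain methyl, a cyclopentylmethyl or a morpholin-4-ylmethyl group at the same carbon would help to settle. From the compounds shown here alone, it also remains open how a hydrogen at this carbon would compare with chloro, and whether a carboxylic acid or a longer chain ending in an amine would be tolerated there.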